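Pyrimidine isomer swap on the sulfonamide nitrogen

The compounds below may be only part of what the source reports. "The series", "measured", "known", "first", "only" and "open" are said of these compounds alone.

Measured so far in a physicochemical assay for lipophilicity; on this read-out lower numbers stand for lower lipophilicity and higher numbers for higher lipophilicity:
- compound 1 (`O=S(=O)(Nc1nccs1)c1ccc2c(c1)OCC[C@@H]2c1ccc(C(F)(F)F)cc1-c1ccc(F)cn1`) at 3.5 
- compound 2 (`O=S(=O)(Nc1ccncn1)c1ccc2c(c1)OCC[C@@H]2c1ccc(C(F)(F)F)cc1-c1ccc(F)cn1`) at 3 

Compound 2 holds the lower of the two numbers, and its gap to compound 1 lies beyond the scatter. Compound 3 (`O=S(=O)(Nc1ncccn1)c1ccc2c(c1)OCC[C@@H]2c1ccc(C(F)(F)F)cc1-c1ccc(F)cn1`) carries pyrimidin-2-yl in place of pyrimidin-4-yl on a sulfonamide nitrogen. Within the data shown here, one measured step bears on this only indirectly: the modest change a number 0.50 log units lower from compound 1 to compound 2 (beyond the scatter), beyond the scatter, replaced 1,3-thiazol-2-yl with pyrimidin-4-yl. Among the measured compounds shown here, no measured pair tests a swap between the two pyrimidine isomers, so the expectation stays anchored on compound 2 at 3. In this assay no clear direction is expected, and the expected step (a number 0.10 log units higher from compound 2 to compound 3 (within the scatter)) stays within the scatter. For compound 3 the estimate is 3.1 (expected range 2.6 to 3.6).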

Compound 3, distribution coefficient: 2.9
Beside the measured number, compound 3's estimate is 0.20 log units above it, within the range that was stated.
By their numbers in this assay, from the lowest: compounds 3 and 2 (each within the scatter of the next); then compound 1.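

In this assay, pyrimidin-2-yl in place of pyrimidin-4-yl on the sulfonamide nitrogen gives a number 0.10 log units lower from compound 2 to compound 3 (within the scatter) and so the two isomers, built from the same atoms joined differently, cannot be told apart on this read-out. Pyrimidin-2-yl in place of 1,3-thiazol-2-yl gives a number 0.60 log units lower from compound 1 to compound 3 (beyond the scatter) and pairs with a number 0.50 log units lower from compound 1 to compound 2 (beyond the scatter) in showing that both pyrimidine isomers stand apart from 1,3-thiazol-2-yl at this position. No measurement at hand accounts for either step.

Open, on these data alone, is how a pyridin-2-yl or 1,3-oxazol-2-yl group would read on the same sulfonamide nitrogen, and whether a methyl group or an amine on the pyrimidin-2-yl ring would shift the number. Also open, as far as these compounds go, is whether the two isomers stay this close on any other read-out or on a different core.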